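Propargyl to benzyl on the ether oxygen

The source may hold more compounds than are shown below. What is called first, only, known or untested is meant among the compounds shown, and "the series" means these compounds.

Compound 1 (`OC(c1cccs1)c1cc2ccccc2nc1Cl`) gives 80600 nM
Compound 2 (`C#CCOC(c1cccs1)c1cc2ccccc2nc1Cl`) gives > 100000 nM as a limit of the assay, not a number
Compound 3 (`Oc1ccc(-c2cc(COC(c3cccs3)c3cc4ccccc4nc3Cl)on2)cc1`) gives "not active" (no number reported)

In a functional assay on MCF7 cells (Homo sapiens) for inhibition, read by WST assay, with stated times of 72 h and 2 h (on this read-out higher numbers stand for weaker inhibition and lower numbers for stronger inhibition), compound 2 reads > 100000 nM which is a limit and not a number. It therefore stands at (the limit of > 100000 nM in this assay, at which 1 of the 3 values shown sits) and offers no exact starting point. Compound 4 (`Clc1nc2ccccc2cc1C(OCc1ccccc1)c1cccs1`) has yet to be measured. It differs from compound 2 in one place (phenyl in place of ethynyl on a saturated chain carbon bound to an oxygen on a saturated carbon), with phenyl in place of ethynyl on a saturated chain carbon bound to an oxygen on a saturated carbon, so that propargyloxy gives way to benzyloxy.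

Among the measured compounds shown here, only one measured step bears on this change (an at least 1.2-fold higher number from compound 1 to compound 2 (0.09 log units; that floor lies within the scatter)), and its floor lies within the scatter. For the measured compounds named here, compound 1 at 80600 nM is the only compound with a full number. Going by the values given here, compound 3 at "not active" (no number reported) adds no size of step. With that single step as the guide (an at least 1.2-fold higher number from compound 1 to compound 2 (0.09 log units; that floor lies within the scatter)), no step beyond the scatter is expected in this assay and no direction can be favoured. The expected step is small (a number no higher from compound 2 to compound 4 (the limit leaves the size open)). The estimate for compound 4 is 100000 nM with an expected range from 40000 nM to 200000 nM and a limit reading remains quite possible.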

Compound 4, half-maximal inhibitory concentration: 108000 nM
Estimate against measurement, compound 4: 1.1-fold (0.03 log units) below, within the range that was stated.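

In this assay, among the compounds shown here, compound 4 supplies the only full number for a group on this oxygen, and the comparison with the free alcohol reads a 1.3-fold higher number from compound 1 to compound 4 (0.13 log units; within the scatter). Benzyl in place of hydrogen, which brings one six-membered aromatic ring of carbon only, therefore leaves compound 1 and compound 4 within the scatter of each other, a comparison that the propargyl ether could give only as a floor. The step from compound 2 to compound 4 cannot be read, as compound 2 stands at a limit and not at a number: the limit of > 100000 nM in this assay, at which 1 of the 4 values shown sits.

From the compounds shown here alone, whether a group of another kind on this oxygen, such as a chain ending in an amine or a carboxylic acid, would give a number clearly apart from that of compound 1 stays open. Also open, going by these compounds, is whether a change elsewhere on the shared core, with the oxygen and its group left as they are, would move the number beyond the scatter.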